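This account rests on a few compounds, and the source may have more. Where it says the series, first, only, none or still open, it means among the compounds named here.

Compound 1 `Cc1ncnc2c1c(-c1cc3ccccc3o1)cn2[C@@H]1O[C@H](CO)[C@@H](O)[C@H]1O` — > 20000 nM
Compound 2 `Cc1ncnc2c1c(-c1ccoc1)cn2[C@@H]1O[C@H](CO)[C@@H](O)[C@H]1O` — > 20000 nM
Compound 3 `Nc1nc(N)c2c(-c3ccoc3)cn([C@@H]3O[C@H](CO)[C@@H](O)[C@H]3O)c2n1` — > 20000 nM

In a functional assay on A549 cells (Homo sapiens), read by MTT assay, with a stated time of 72 h (a lower number here means a stronger inhibitor, a higher number a weaker inhibitor), compound 1 gives > 20000 nM, which is a limit of the assay and not a number. Compound 2 gives > 20000 nM in this assay, again only a limit. Compound 3 gives > 20000 nM in this assay, and this too is a limit rather than a number. The change 1-benzofuran-2-yl in place of furan-3-yl on an aromatic carbon therefore produced a step that the two limits leave unreadable from compound 2 to compound 1, since both of its ends sit at the same limit. The two cores of compound 2 and compound 3 differ as well, but the difference between them is not broken down here.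

Compound 4 `Nc1nc(N)c2c(-c3cc4ccccc4o3)cn([C@@H]3O[C@H](CO)[C@@H](O)[C@H]3O)c2n1` has not yet been measured in this assay. It differs from compound 3 by 1-benzofuran-2-yl in place of furan-3-yl on an aromatic carbon, the same change that leads from compound 2 to compound 1, at the same place on the shared core. Nothing measured among these three compounds shows that this change moves the value at all, because the limit of > 20000 nM in this assay, at which 3 of the 3 values shown sit, is where every value so far sits. On that footing compound 4 is expected to show the step that the limit leaves unreadable from compound 3 to compound 4 from compound 3, which is an estimate resting on the same limit. Compound 4 is accordingly estimated at 30000 nM in this assay, with an expected range from 10000 nM to 100000 nM, and it is most likely that the assay will once more report only a limit and no number.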

Compound 4, half-maximal inhibitory concentration: > 20000 nM
Compound 4: only a limit was reported; the forecaster's own chance of this, stated with the estimate: 85%; the middle value lies beyond the limit too.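

In this assay compound 4 gives > 20000 nM, which is a limit of the assay and not a number. Compound 3 also sits at a limit, so no new step can be read between compound 3 and compound 4. Compounds 1 to 4 leave open whether exchanging furan-3-yl for 1-benzofuran-2-yl, or changing the core, moves the value at all, as they offer only one reading: the limit of > 20000 nM in this assay, at which 4 of the 4 values shown sit.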